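Exchanging 2-Aminoethyl for (Aminomethyl)carbonyl: Expected Tolerance

The source may report more compounds than this note shows. Statements on the series, on what has been measured and on what is new or still open speak of the compounds shown alone.

Three compounds have so far been examined in an ADME assay on HEp-2 cells (Homo sapiens) for cytotoxicity, read by CCK-8 assay, with a stated time of 5 days; a higher number here means that more compound is tolerated, a lower number that less compound is tolerated. Compound 1 `OCC(O)CNc1cc(N2CCc3ccccc3C2)nc2ccccc12` carries a hydroxy on a saturated chain carbon and gives 66000 nM. Compound 2 `CC(O)CNc1cc(N2CCc3ccccc3C2)nc2ccccc12` has a hydrogen in that place and gives 89000 nM; the step of a 1.3-fold higher number from compound 1 to compound 2 (0.13 log units; within the scatter) is the only one that can be followed between two numbers, and it does not leave the scatter. Compound 3 `Cc1ccc2nc(N3CCCc4ccc(F)cc4C3)cc(NCCN)c2c1` rests on a different core, and in this assay its result is a limit of the assay rather than a number, > 3200 nM, as the limit of > 3200 nM in this assay, at which 1 of the 3 values shown sits, shows.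

Compound 4 `Cc1ccc2nc(N3CCCc4ccc(F)cc4C3)cc(NC(=O)CN)c2c1` differs from compound 3 in one place: (aminomethyl)carbonyl in place of 2-aminoethyl on a nitrogen on an aromatic ring. Within the data shown here, no measured step touches an exchange of this kind. The step from compound 1 to compound 2 concerns a hydroxy against a hydrogen and stays within the scatter, so it offers neither size nor direction for the present change. The expectation for compound 4 in this assay therefore rests on the limit of compound 3 and on the span covered by compound 1 and compound 2. The estimated step that the limit leaves unreadable from compound 3 to compound 4 is expected to stay within the scatter. Compound 4 is thus expected to sit near 30000 nM, between 3200 nM and 100000 nM, with a fair chance that this assay again reports only a limit.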

Compound 4, half-maximal cytotoxic concentration: > 100000 nM
Compound 4: a limit, no number; the forecaster's own chance of this, stated with the estimate: 60%; middle value at least 3.3-fold (0.52 log units) away from the limit.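

In this assay compound 3 gives only a limit, > 3200 nM. Compound 4 likewise gives only a limit, > 100000 nM, and no step can be read between these two compounds. The compounds shown leave open how large the change from 2-aminoethyl to (aminomethyl)carbonyl is in this read-out, and in which direction it runs.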